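A few compounds are considered here, and "the series" means these few. Any claim that something is new, unique, unknown or untested is made for them only; others in the source may bear on it.

Compound 1 `FC(F)(F)c1ccc(CNc2nc(-c3ccccc3C(F)(F)F)nc3ccccc23)cc1` and compound 2 `FC(F)(F)c1ccccc1-c1nc(NCc2ccc(-c3cncnc3)cc2)c2ccccc2n1` share one core and differ at a single aromatic carbon. In an assay on a protein complex for inhibition of ubiquitin carboxyl-terminal hydrolase 1/WD repeat-containing protein 48 (Homo sapiens), read by fluorescence (a higher number here means a weaker inhibitor, a lower number a stronger inhibitor), compound 1 gives 8900 nM, and compound 2 gives 3000 nM. Within the data shown here, the step of a 3.0-fold lower number from compound 1 to compound 2 (0.47 log units; beyond the scatter) is the only measured step, and it leaves compound 2 with the lowest of the two numbers.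

Compound 3 `FC(F)(F)c1ccccc1-c1nc(NCc2ccc(C3CCCCC3)cc2)c2ccccc2n1` has not yet been measured. It differs from compound 2 by cyclohexyl in place of pyrimidin-5-yl on an aromatic carbon. The measured step bears on this only loosely: it exchanged trifluoromethyl for pyrimidin-5-yl at the same place, whereas here pyrimidin-5-yl gives way to cyclohexyl, a group with no hydrogen-bond acceptors. Among the measured compounds shown here, no measured pair shows cyclohexyl at this place, so the direction is open and the expected step is modest. Compound 3 is expected to give about 5000 nM in this assay, between 1500 nM and 16000 nM. This corresponds to an expected step of a 1.7-fold higher number from compound 2 to compound 3 (0.22 log units; within the scatter).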

Compound 3, half-maximal inhibitory concentration: 9800 nM
For compound 3 the middle estimate is 2.0-fold (0.29 log units) below the measured one; the range from low to high includes it.
By their numbers in this assay, from the lowest: compound 2; then compounds 1 and 3 (each within the scatter of the next).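

At this position on the aromatic ring, the step of a 3.3-fold higher number from compound 2 to compound 3 (0.51 log units; beyond the scatter) in this assay shows that the advantage of compound 2 does not carry over to cyclohexyl, a single ring of carbon only without hydrogen-bond acceptors. The step of a 1.1-fold higher number from compound 1 to compound 3 (0.04 log units; within the scatter) leaves cyclohexyl and trifluoromethyl indistinguishable here, so among these three groups only pyrimidin-5-yl stands apart, with compound 2 beyond the scatter of both compound 1 and compound 3. Nothing available accounts for this difference.

The change from pyrimidin-5-yl to cyclohexyl removes the aromatic ring and the ring nitrogens together, so the compounds shown cannot separate the two. Phenyl, which keeps the aromatic ring without nitrogen, and piperidine, which keeps a ring nitrogen without aromaticity, would each address one side of that question.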